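A second hydroxy on compound 2

This account rests on a few compounds, and the source may have more. Where it says the series, first, only, none or still open, it means among the compounds named here.

In a functional assay on SK-BR-3 cells (Homo sapiens) for cytotoxicity, read by sulforhodamine B assay, with a stated time of 72 h (a higher number here means that more compound is needed for the effect, a lower number that less compound is needed), compound 1 (`Cc1coc2cc(-c3cccc(O)c3)oc(=O)c12`) gives 1.61 uM and compound 2 (`Cc1coc2cc(-c3ccc(O)cc3)oc(=O)c12`) gives 36 uM as its read-out. Compound 2 thus holds the higher of the two numbers, beyond the scatter from compound 1, so more of it is needed for the effect. Compound 3 (`Cc1coc2cc(-c3ccc(O)c(O)c3)oc(=O)c12`) follows from compound 2 by hydroxy in place of hydrogen on an aromatic carbon with hydroxy in place of hydrogen on an aromatic carbon, ortho to a hydroxy group and meta to a large group. Going by the values given here, no measured step of this kind exists to size the change. Compound 1, at 1.61 uM, carries a hydroxy meta to a large group, as compound 3 would. On that single comparison, an estimated step of a 6.0-fold lower number from compound 2 to compound 3 (0.78 log units; beyond the scatter) is expected, towards a lower number and beyond the scatter. The estimate for compound 3 is 6 uM, with an expected range of 1.5 uM to 30 uM in this assay.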

Compound 3, concentration for half-maximal effect: 0.47 uM
Compound 3: the middle estimate sits 13-fold (1.11 log units) above what was measured, outside the stated range (below it).
By their numbers in this assay, from the lowest: compound 3; then compound 1; then compound 2.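

In this assay, hydroxy in place of hydrogen on an aromatic carbon, ortho to a hydroxy group and meta to a large group, gives a 77-fold lower number from compound 2 to compound 3 (1.88 log units; beyond the scatter) and so turns the weakest compound of the series into the strongest. Read from the other single-hydroxy compound, adding a hydroxy gives only a 3.4-fold lower number from compound 1 to compound 3 (0.53 log units; beyond the scatter) and is a modest step, so the second hydroxy lowers the number in both cases but by very different amounts. Nothing at hand bears on why these two steps differ.

On these data alone, whether this large step is specific to hydroxy remains open, as the series offers only hydroxy and hydrogen at this place. A methoxy or an amine there, with the other hydroxy kept, would test that.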